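Reversed amide on the acyl side chain of compound 1

The compounds below may be only part of what the source reports. "The series", "measured", "known", "first", "only" and "open" are said of these compounds alone.

Working notes on a small set of thiazolidine amides tested in a functional assay on the whole organism for inhibition, with Cavia porcellus as the target; a higher number here means that more compound is needed for the effect, a lower number that less compound is needed. Compound 1 `COc1ccccc1OCC1SCCN1C(=O)CNC(C)=O` gives 40 mg/kg in this assay, the highest of the three numbers in hand, yet both other compounds sit within the scatter of it. Compound 2 `CCOC(=O)CC(=O)N1CCSC1COc1ccccc1O` gives 20 mg/kg in this assay, and compound 3 `COc1ccccc1OCC1N(C(=O)CC(=O)O)CC[S+]1[O-]` gives 20 mg/kg in this assay; neither gap from compound 1 is beyond the usual scatter, so no order among the three can be read from these numbers. Among the measured compounds shown here, no pair of measured compounds differs in one place only, so no single-step change has a measured size here.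

Compound 4 `CNC(=O)CC(=O)N1CCSC1COc1ccccc1OC` has not been measured. It differs from compound 1 as follows: methylcarbamoyl in place of acetamido on a saturated chain carbon bound to a carbonyl carbon. The two compounds carry the same atoms joined differently, so the change is small in size. For the measured compounds named here, with no measured step of this kind to lean on, the expectation is that the step from compound 1 to compound 4 will be a 1.3-fold lower number from compound 1 to compound 4 (0.12 log units; within the scatter), that is, within the scatter rather than a clear shift in either direction. Compound 4 is therefore estimated at 30 mg/kg in this assay, with a range from 10 mg/kg to 90 mg/kg.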

Compound 4, dose for half-maximal effect: 21 mg/kg
Beside the measured number, compound 4's estimate is 1.4-fold (0.15 log units) above it; low and high end bracket the measured number.
By their numbers in this assay, from the lowest: compounds 2, 3, 4 and 1 (each within the scatter of the next).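

Among the compounds shown here, this is the first pair that differs in one place only, so the first step with a measured size: in this assay the exchange of acetamido for methylcarbamoyl on a saturated chain carbon bound to a carbonyl carbon reads a 1.9-fold lower number from compound 1 to compound 4 (0.28 log units; within the scatter) and does not separate the two compounds. Joining the same atoms the other way round, with the donor and acceptor counts unchanged, therefore gives no readable shift at this place, and either arrangement of the amide is compatible with a number in the range of the series so far. Nothing measured here bears on why the two compounds read alike.

The compounds shown leave open whether this place tolerates changes larger than a rearrangement of the same atoms, such as a dimethylcarbamoyl group, which has no amide hydrogen, or a longer chain such as ethylcarbamoyl. A basic group such as an aminomethyl chain at the same place is also untested by these compounds, and a one-place comparison of that kind against compound 1 or compound 4 would show whether this side chain can move the number beyond the scatter at all.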